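Swapping the Aryl Group on a Weak mGlu5 Modulator

The compounds below may be only part of what the source reports. "The series", "measured", "known", "first", "only" and "open" are said of these compounds alone.

Compound 2 `Cc1ccc(-c2noc(C3CCc4c(nnn4C(C)(C)C)C3)n2)cn1` was tested in a functional assay on U2OS cells for positive allosteric modulation of metabotropic glutamate receptor 5 (Homo sapiens), read by calcium flux, in the presence of a further agent that is not named here (a higher number here means that more compound is needed for the effect, a lower number that less compound is needed), where compound 2 gives 1580 nM. Of the two compounds with numbers, compound 2 stands highest; the only other, compound 1 `CC1(n2nnc3c2CCC(c2nc(-c4ccc(F)cc4)no2)C3)CCOCC1`, gives 10 nM, a gap well beyond the usual scatter. Among the measured compounds shown here, compound 1 differs from compound 2 at more than one place, so it shows only that a far lower number can be reached with this shared core.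

Compound 3 `CC(C)(C)n1nnc2c1CCC(c1nc(-c3ccc(C#N)cc3)no1)C2` is compound 2 with one change: 4-cyanophenyl in place of 6-methylpyridin-3-yl on an aromatic carbon. For the measured compounds named here, no step of this exact kind has been measured here, so the direction is a judgement. Because compound 1 reaches 10 nM with a carbon-only aromatic ring at this position, compound 3 is expected to move downward, a step of a 13-fold lower number from compound 2 to compound 3 (1.12 log units; beyond the scatter) in this assay. The estimate for compound 3 is 120 nM, within a range from 25 nM to 600 nM.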

Compound 3, half-maximal effective concentration: 79.4 nM
For compound 3 the middle estimate is 1.5-fold (0.18 log units) above the measured one; the measured number falls inside the stated range.
By their numbers in this assay, from the lowest: compound 1; then compound 3; then compound 2.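

With the rest of the molecule held fixed, putting 4-cyanophenyl in place of 6-methylpyridin-3-yl gives a 20-fold lower number from compound 2 to compound 3 (1.30 log units; beyond the scatter) in this assay. Among the compounds shown here, this is the first direct reading of this position, on the aromatic carbon two ring bonds from the ring oxygen, and it shows that the choice of aromatic group here can shift the number well beyond the scatter; compound 1 could not show this, as it differs from compound 2 at more than one place. The swap alters the ring and its substituent together, and no measurement at hand explains the step.

On these data alone, it remains open whether the carbon-only ring or the nitrile accounts for the step; a plain phenyl group or a cyanopyridinyl group would separate the two. Also open, as far as these compounds go, is how a 4-methoxyphenyl group or an aminophenyl group would fare at this carbon.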